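Removing the second chloro from the dichloropurine benzyl series

The source may report more compounds than this note shows. Statements on the series, on what has been measured and on what is new or still open speak of the compounds shown alone.

Two compounds of the series have numbers in a functional assay on LOX IMVI cells (Homo sapiens) for cytotoxicity, read by sulforhodamine B assay, with a stated time of 48 h; a higher number here means that more compound is tolerated, a lower number that less compound is tolerated. Compound 1 `ClCc1ccc(Cn2cnc3c(Cl)ncnc32)cc1` gives 13500 nM. Compound 2 `ClCc1ccccc1Cn1cnc2c(Cl)nc(Cl)nc21` gives 850 nM, the lower of the two, and the gap to compound 1 lies beyond the scatter. The step now followed leads to compound 3 `ClCc1ccccc1Cn1cnc2c(Cl)ncnc21`, which is compound 2 with hydrogen in place of chloro on an aromatic carbon. Among the compounds with values here, no measured pair shows this change directly. Compound 3 is expected to sit higher than compound 2, with the estimated step of a 4.7-fold higher number from compound 2 to compound 3 (0.67 log units; beyond the scatter) in this assay likely beyond the scatter. The expected value for compound 3 is 4000 nM, in a range from 1200 nM to 14000 nM.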

Compound 3, concentration lethal to 50% of the cells: > 100000 nM
Compound 3 was reported as a limit; the forecaster's own chance of this, stated with the estimate: 5%; at least 25-fold (1.39 log units) between middle value and limit.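

In this assay, hydrogen in place of chloro on the aromatic carbon between two ring nitrogen atoms gives an at least 110-fold higher number from compound 2 to compound 3 (2.07 log units; beyond the scatter). Within the data shown here, compounds 1 and 2 differ in more than one place, and this pair gives the first reading of this change alone. Compound 3 stands as a limit of the assay, not as a number: the limit of > 100000 nM in this assay, at which 1 of the 3 values shown sits.

As far as these compounds go, the true size of the step stays open. Also open, from the compounds shown here alone, is whether an amine or a methoxy group on this carbon would keep a number near that of compound 2.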